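Two Limits, Then a Smaller Group on the Shared Core

The source may report more compounds than this note shows. Statements on the series, on what has been measured and on what is new or still open speak of the compounds shown alone.

Compound 1 `Cn1c(C(=O)N2CCOCC2)cc2cc(OCCCC3CCN(Cc4ccccc4)CC3)ccc21` and compound 2 `C#CCNC(=O)c1cc2cc(OCCCC3CCN(Cc4ccccc4)CC3)ccc2n1C` share one core and differ only at the carbonyl carbon, where compound 2 carries propargylamino in place of morpholin-4-yl. In an assay on isolated protein for inhibition of Amine oxidase [flavin-containing] A (Homo sapiens), read by fluorescence, with stated times of 30 min and 1 h (a lower number here means a stronger inhibitor, a higher number a weaker inhibitor), compound 1 gives only a limit, > 100000 nM. In this assay compound 2 likewise gives only a limit, > 100000 nM. The step that the two limits leave unreadable from compound 1 to compound 2 cannot be sized, since both values sit at the limit of > 100000 nM in this assay, at which 2 of the 2 values shown sit. Compound 2 therefore stands at the edge of this assay, with no measured number to place it.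

Compound 3 `Cn1c(CO)cc2cc(OCCCC3CCN(Cc4ccccc4)CC3)ccc21` is the next member: hydroxymethyl in place of propargylcarbamoyl on an aromatic carbon. Among the compounds with values here, the one measured step near this position, a step that the two limits leave unreadable from compound 1 to compound 2, carries neither size nor direction, so nothing measured points to a gain or a loss in this assay for the new group. Compound 3 is expected to show a step of a number no higher from compound 2 to compound 3 (the limit leaves the size open) that is guessed rather than derived. Compound 3 is expected to give about 100000 nM, within a range from 20000 nM to 300000 nM, most likely reported once more as a limit.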

Compound 3, half-maximal inhibitory concentration: 4260 nM
Estimate against measurement, compound 3: 23-fold (1.37 log units) above, outside the stated range (below it).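

In this assay this position now gives its first readable steps: hydroxymethyl in place of propargylcarbamoyl gives an at least 23-fold lower number from compound 2 to compound 3 (1.37 log units; beyond the scatter), and hydroxymethyl in place of (morpholin-4-yl)carbonyl gives an at least 23-fold lower number from compound 1 to compound 3 (1.37 log units; beyond the scatter). The change therefore shows that the group on this aromatic carbon can move the read-out by a large amount, which the unreadable step between the two amides could not show, and that compound 3 gets there with fewer heavy atoms than propargylcarbamoyl while keeping the same counted hydrogen-bond donor and acceptor. Compound 3 is the only one of the three with a measured number, and the other two stay at the edge of the assay: the limit of > 100000 nM in this assay, at which 2 of the 3 values shown sit.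

The compounds shown do not separate the effect of the shorter group from that of losing the carbonyl, or from that of the free hydroxyl itself. As far as these compounds go, an aminomethyl or methoxymethyl group at this position, or a carboxylic acid, would bear on that question, and the full size of both steps stays open since each starts from a limit.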